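Compound 1 and the step to a 4-fluorophenyl group

The source may hold more compounds than are shown below. What is called first, only, known or untested is meant among the compounds shown, and "the series" means these compounds.

Compound 1 `O=C1COc2ccc(-c3cnc(Cl)c(NS(=O)(=O)c4ccc(F)cc4)c3)cc2N1C1CCCCC1` gives 37900 nM
Compound 2 `COc1ncc(-c2ccc3c(c2)NC(=O)CO3)cc1NS(=O)(=O)c1ccc(F)cc1` gives 8070 nM
Compound 3 `COc1ncc(-c2ccc3c(c2)N(C2CCCCC2)C(=O)CO3)cc1NS(=O)(=O)c1ccc(F)cc1` gives 24600 nM

Among the compounds with values here, all three values come from a functional assay on A549 cells (Homo sapiens) for antiproliferative activity, read by MTT assay, with a stated time of 72 h (on this read-out lower numbers stand for stronger inhibition and higher numbers for weaker inhibition), and are the only evidence available here. Compound 1 with 37900 nM lies well above compound 2 and level with compound 3 within the scatter. Compound 4 `O=C1COc2ccc(-c3cnc(Cl)c(NS(=O)(=O)c4ccc(F)cc4)c3)cc2N1c1ccc(F)cc1` differs from compound 1 at one place, with 4-fluorophenyl in place of cyclohexyl on an amide-type nitrogen in a ring as the whole change. Within the data shown here, no measured step makes this exact exchange. The closest is a 3.0-fold higher number from compound 2 to compound 3 (0.48 log units; beyond the scatter) for cyclohexyl in place of hydrogen on that same nitrogen, a modest step beyond the scatter. The step of a 1.5-fold lower number from compound 1 to compound 3 (0.19 log units; within the scatter) concerns methoxy in place of chloro, so it bears on the change only by showing how little separates the two cyclohexyl compounds. Among the measured compounds shown here, with only that modest step as a guide, the expected change in this assay is a 1.3-fold lower number from compound 1 to compound 4 (0.10 log units; within the scatter) and thus nothing beyond the scatter. Compound 4 is estimated at 30000 nM with an expected range of 12000 nM to 70000 nM when it is measured.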

Compound 4, half-maximal inhibitory concentration: 22300 nM
For compound 4 the middle estimate is 1.3-fold (0.13 log units) above the measured one; the measured number falls inside the stated range.
By their numbers in this assay, from the lowest: compound 2; then compounds 4, 3 and 1 (each within the scatter of the next).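

In this assay the exchange of cyclohexyl for 4-fluorophenyl on the amide-type nitrogen gives a 1.7-fold lower number from compound 1 to compound 4 (0.23 log units; within the scatter) and so leaves the read-out within the scatter. The earlier compounds shown here showed this nitrogen only with cyclohexyl against hydrogen, with methoxy on the core; compound 4 adds an aromatic ring with a fluorine at the same place, with chloro on the core, and in this pair the swap from a non-aromatic to an aromatic six-membered ring does not separate the two compounds. Nothing available here explains why the two compounds stay so close.

The compounds shown leave open whether the amide hydrogen would give the same step with chloro on the core as it does with methoxy. They also leave open how a carboxylic acid, an amine or a longer chain on this nitrogen would read out.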